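Swapping a thiophene ring for phenyl on a shared pyridine-free core

The source may hold more compounds than are shown below. What is called first, only, known or untested is meant among the compounds shown, and "the series" means these compounds.

Measured compounds in a functional assay on DU-145 cells (Homo sapiens) for cytotoxicity, read by CCK-8 assay and cell counting, with a stated time of 2 days; on this read-out higher numbers stand for weaker inhibition and lower numbers for stronger inhibition:
- compound 1, `Oc1cccc(-c2cc(-c3ccsc3)nc(-c3cccc(Cl)c3)c2)c1`: 3330 nM
- compound 2, `Oc1ccc(-c2cc(-c3ccsc3)nc(-c3cccc(Cl)c3)c2)cc1`: 6220 nM
- compound 3, `Oc1cccc(-c2cc(-c3ccsc3)nc(-c3ccccc3Cl)c2)c1`: 1970 nM

Among these three numbers, compound 1 stands second highest. Its nearest neighbour is compound 3, reached by a 1.7-fold lower number from compound 1 to compound 3 (0.23 log units; within the scatter), and its furthest is compound 2, reached by a 1.9-fold higher number from compound 1 to compound 2 (0.27 log units; within the scatter). Both steps stay within the usual scatter, so the three compounds cannot be told apart on these readings.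

Compound 4, `Oc1cccc(-c2cc(-c3ccccc3)nc(-c3cccc(Cl)c3)c2)c1`, has not yet been measured. It differs from compound 1 in one place: phenyl in place of thiophen-3-yl on an aromatic carbon. The change sits on an aromatic carbon of a six-membered aromatic ring with 1 nitrogen, next to the ring nitrogen, meta to a 3-chlorophenyl group and meta to a 3-hydroxyphenyl group.

Neither measured step touches this position; they vary the hydroxyphenyl and chlorophenyl groups only, and each stays within the scatter. There is therefore no direct guide to what exchanging thiophen-3-yl for phenyl does, and no reason from these data to expect a shift beyond the scatter in either direction in this assay.

Compound 4 is accordingly estimated at 3300 nM, with a range from 1200 nM to 9000 nM. This expectation amounts to a 1.0-fold lower number from compound 1 to compound 4 (0.00 log units; within the scatter).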

Compound 4, half-maximal inhibitory concentration: 2750 nM
For compound 4 the middle estimate is 1.2-fold (0.08 log units) above the measured one; low and high end bracket the measured number.
By their numbers in this assay, from the lowest: compounds 3, 4, 1 and 2 (each within the scatter of the next, the first and the last beyond it).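

In this assay, this is the first change shown at this position on the shared core, and exchanging thiophen-3-yl for phenyl gives a 1.2-fold lower number from compound 1 to compound 4 (0.08 log units; within the scatter). The two rings differ in size, in the sulfur atom and in the count of hydrogen-bond acceptors, yet on this read-out compound 1 and compound 4 cannot be told apart, so for this one pair those differences leave no readable mark on the number. Nothing measured here says why the two rings read alike.

The compounds shown leave open whether the same exchange would read alike with the other partner groups on the core, such as the 2-chlorophenyl group of compound 3 or the 4-hydroxyphenyl group of compound 2, since phenyl appears here only with the 3-chlorophenyl and 3-hydroxyphenyl pair. They also leave open how far this position can depart from a flat aromatic ring. Only two such rings are shown there, and an amine, a carboxylic acid or a longer alkyl chain in the same place could give a step beyond the scatter or none at all.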